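The compounds below may be only part of what the source reports. "The series", "measured", "known", "first", "only" and "open" are said of these compounds alone.

Compound 1, `O=C(Nc1ccc(C(F)(F)F)cc1)c1cc(Br)c(F)cc1O`, gives 820 nM in a functional assay on KG-1 cells (Homo sapiens) for cytotoxicity, read by luminescence and CellTiter-Glo, with a stated time of 3 days; on this read-out higher numbers stand for weaker inhibition and lower numbers for stronger inhibition.
Compound 2, `N#Cc1ccc(NC(=O)c2ccc(-c3ccccc3)cc2O)cc1`, gives 410 nM in this assay.
Compound 3, `O=C(Nc1ccc(C(F)(F)F)cc1)c1ccc(F)cc1O`, gives 740 nM in this assay.

The three measured compounds lie close together on this read-out; the gaps between compound 2 and compound 3 and between compound 2 and compound 1 are both within the usual scatter, so no order among them can be claimed. One structural change is seen directly. From compound 3 to compound 1 the change is bromo in place of hydrogen on an aromatic carbon, and the step is a 1.1-fold higher number from compound 3 to compound 1 (0.04 log units; within the scatter). How the core of compound 2 differs from the core of compound 3 is not broken down here.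

Compound 4, `N#Cc1ccc(NC(=O)c2cc(Br)c(-c3ccccc3)cc2O)cc1`, has not yet been measured in this assay. It differs from compound 2 by bromo in place of hydrogen on an aromatic carbon. For the measured compounds named here, this is the same kind of change as the one from compound 3 to compound 1, but not the same: in compound 1 the entering bromo sits ortho to a fluoro group, whereas in compound 4 it sits ortho to a phenyl group; in both it is meta to a large group and para to a hydroxy group. Because the earlier step of a 1.1-fold higher number from compound 3 to compound 1 (0.04 log units; within the scatter) stayed within the scatter, the step from compound 2 to compound 4 is expected to be small as well, about a 1.1-fold higher number from compound 2 to compound 4 (0.04 log units; within the scatter). Compound 4 is therefore estimated at 450 nM in this assay, with the expectation that it falls between 200 nM and 1000 nM.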

Compound 4, half-maximal inhibitory concentration: 850 nM
The estimate for compound 4 lay 1.9-fold (0.28 log units) below the measured number; the measured number falls inside the stated range.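

In this assay, bromo in place of hydrogen on an aromatic carbon gives a 2.1-fold higher number from compound 2 to compound 4 (0.32 log units; beyond the scatter), a modest step on the core of compound 2. Set beside the same change on the core of compound 3, the two steps cannot be told apart: the same change on two cores in this assay, a 1.1-fold higher number (0.04 log units; within the scatter) from compound 3 to compound 1 and a 2.1-fold higher number (0.32 log units; beyond the scatter) from compound 2 to compound 4, 1.9-fold (0.27 log units) apart, within the scatter of two such steps

This shows that the change can be carried between these two cores without a difference that can be claimed, even though only the new step lies beyond the scatter. For the compounds shown here, it does not show that bromo has the same effect on both cores or on any other core, and with only two steps it cannot separate the influence of the core from that of the phenyl group to which the bromo is ortho in compound 4.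

The compounds shown hold only bromo at this place, leaving open how a chloro, a methyl or a methoxy group there would read in this assay. They also leave open what an amine or a carboxylic acid in place of the hydroxy group, or a longer chain in place of the phenyl group, would do.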